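Swapping Isopropyl for Trifluoromethyl on a Substance-P Ligand

A few compounds are considered here, and "the series" means these few. Any claim that something is new, unique, unknown or untested is made for them only; others in the source may bear on it.

Three compounds share one core, first seen in compound 1 `c1ccc(C2CCC3(OCCNC3c3ccccc3)OC2)cc1`. In an assay on CHO cells for displacement of a labelled ligand from Substance-P receptor (Homo sapiens) (on this read-out higher numbers stand for weaker inhibition and lower numbers for stronger inhibition), compound 1 gives 170 nM. Compound 2 `COc1ccc(F)cc1[C@H]1COCC2(C1)OCCN[C@H]2c1ccc(F)cc1` gives 10 nM in this assay, and compound 3 `COc1ccc(C(C)C)cc1[C@H]1COCC2(C1)OCCN[C@H]2c1ccc(F)cc1` gives 2.8 nM, the lowest of the three numbers. Among the measured compounds shown here, the only measured step at the aromatic carbon in question is a 3.6-fold lower number from compound 2 to compound 3 (0.55 log units; beyond the scatter), a modest gain. Compound 4 `COc1ccc(C(F)(F)F)cc1[C@H]1COCC2(C1)OCCN[C@H]2c1ccc(F)cc1` differs from compound 3 by trifluoromethyl in place of isopropyl on an aromatic carbon, a trifluoromethyl in place of isopropyl, on an aromatic carbon para to a methoxy group. For the measured compounds named here, no measured pair covers this exact exchange, so the expectation rests on that single modest step. For compound 4 only a small step is expected, a 1.4-fold higher number from compound 3 to compound 4 (0.15 log units; within the scatter), likely within the scatter. Compound 4 is therefore estimated at 4 nM, within a range of 1.5 nM to 12 nM.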

Compound 4, half-maximal inhibitory concentration: 1.3 nM
The estimate for compound 4 lay 3.1-fold (0.49 log units) above the measured number, outside the stated range (below it).
By their numbers in this assay, from the lowest: compound 4; then compound 3; then compound 2; then compound 1.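

Trifluoromethyl gives a 2.2-fold lower number from compound 3 to compound 4 (0.33 log units; beyond the scatter) in this assay and a 7.7-fold lower number from compound 2 to compound 4 (0.89 log units; beyond the scatter) at this aromatic carbon, so the position still had room for a lower number after isopropyl. Across the three groups compared here, the number falls from fluoro through isopropyl to trifluoromethyl, an order the single earlier step could not show. Nothing available here explains this order.

Going by these compounds, whether an amine, a carboxylic acid or a longer chain at this carbon would give a lower number remains open. So does whether trifluoromethyl behaves the same way with another group in place of the methoxy group.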